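A few compounds are considered here, and "the series" means these few. Any claim that something is new, unique, unknown or untested is made for them only; others in the source may bear on it.

Compounds measured so far:
compound 1, `CCCS(=O)(=O)N1CCN(C2(CNC(=O)c3ccccc3C(F)(F)F)CCCCC2)CC1`, 48.5 nM in an assay on JAR cells for inhibition of sodium- and chloride-dependent glycine transporter 1 (Homo sapiens), read by scintillation proximity assay; on this read-out higher numbers stand for weaker inhibition and lower numbers for stronger inhibition
compound 2, `CCCS(=O)(=O)N1CCN(C2(CNC(=O)c3cccc(C(F)(F)F)c3Cl)CCCCC2)CC1`, 77.9 nM in this assay

Compound 2 carries the higher of the two numbers, but the step of a 1.6-fold higher number from compound 1 to compound 2 (0.21 log units; within the scatter) lies within the scatter, so compound 1 and compound 2 cannot be told apart on these data. Compound 3, `CCCS(=O)(=O)N1CCN(C2(CNC(=O)c3ccc(F)cc3C)CCCCC2)CC1`, differs from compound 2 by 4-fluoro-2-methylphenyl in place of 2-chloro-3-(trifluoromethyl)phenyl on a carbonyl carbon. Going by the values given here, the only measured step that bears on this change is a 1.6-fold higher number from compound 1 to compound 2 (0.21 log units; within the scatter), likewise an exchange of one substituted phenyl for another on the carbonyl carbon, and it stayed within the scatter. Among the compounds with values here, no measured step shows a fluoro- or methyl-bearing phenyl at this place, so nothing beyond that single comparison can be drawn on. On this basis compound 3 is expected to remain near compound 2, and the step of a 1.2-fold lower number from compound 2 to compound 3 (0.08 log units; within the scatter) is expected to be small, in no direction beyond the scatter. Compound 3 is therefore estimated at 65 nM in this assay, with a range from 20 nM to 200 nM.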

Compound 3, half-maximal inhibitory concentration: 28.1 nM
For compound 3 the middle estimate is 2.3-fold (0.36 log units) above the measured one; the range from low to high includes it.
By their numbers in this assay, from the lowest: compounds 3, 1 and 2 (each within the scatter of the next, the first and the last beyond it).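

In this assay, the exchange on the carbonyl carbon now gives a step beyond the scatter, a 2.8-fold lower number from compound 2 to compound 3 (0.44 log units; beyond the scatter), so this place does not treat all substituted phenyl groups alike, which the earlier pair could not show. Set against 2-(trifluoromethyl)phenyl, the same entering group gives a 1.7-fold lower number from compound 1 to compound 3 (0.24 log units; within the scatter), so 4-fluoro-2-methylphenyl is separated only from 2-chloro-3-(trifluoromethyl)phenyl and not from both groups it can be compared with. Nothing at hand explains this difference.

The two groups in the step to compound 3 differ in several substituents at once, so the compounds shown do not tell which of the fluoro, methyl, chloro or trifluoromethyl groups accounts for the step. From the compounds shown here alone, how a methoxy group or a nitrile on the phenyl would read at this place also remains open.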